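Aromatic substituent swap in a solubility series

The source may hold more compounds than are shown below. What is called first, only, known or untested is meant among the compounds shown, and "the series" means these compounds.

Compound 2 `O=C(Nc1nc(-c2cccc(C(F)(F)F)c2F)cs1)c1cnc(N2CCC(C(=O)O)CC2)c(C(F)(F)F)c1` stands only at a limit in a physicochemical assay for solubility; on this read-out lower numbers stand for lower solubility and higher numbers for higher solubility. In this assay compound 2 gives < 10 ug/mL, a limit of the assay rather than a number. Compound 1 `O=C(Nc1nc(-c2cccc(C(F)(F)F)c2F)cs1)c1cnc(N2CCC(C(=O)O)CC2)c(Br)c1` differs by bromo in place of trifluoromethyl. In this assay compound 1 gives < 10 ug/mL, likewise a limit. The step that the two limits leave unreadable from compound 1 to compound 2 cannot be sized, since both values sit at the limit of < 10 ug/mL in this assay, at which 2 of the 2 values shown sit. Compound 3 `O=C(Nc1nc(-c2cccc(C(F)(F)F)c2F)cs1)c1cnc(N2CCC(C(=O)O)CC2)c(F)c1` carries the change (fluoro in place of trifluoromethyl on an aromatic carbon). For the measured compounds named here, no measured step reads the size of such a change, so no direction beyond the scatter is expected in this assay. Compound 3 is estimated at 8 ug/mL (range 2 ug/mL to 30 ug/mL). That estimate means an expected step that the limit leaves unreadable from compound 2 to compound 3, with a limit again likely.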

Compound 3, solubility: < 10 ug/mL
Compound 3 ended at the assay's limit; the forecaster's own chance of this, stated with the estimate: 60%; the middle value is on the limit's open side.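

No new step can be read in this assay among compound 1, compound 2 and compound 3, because each value is a limit: the limit of < 10 ug/mL in this assay, at which 3 of the 3 values shown sit.

The compounds shown leave open whether bromo, trifluoromethyl and fluoro on this aromatic carbon differ at all in this assay.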